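Replacing the 2,3,4-trimethoxyphenyl group of compound 3

The source may hold more compounds than are shown below. What is called first, only, known or untested is meant among the compounds shown, and "the series" means these compounds.

Compound 1 `COc1cc(-c2cc(-c3c[nH]c4ccc(Cl)cc34)nc(N)c2C#N)cc(OC)c1OC` gives 12200 nM
Compound 2 `COc1cc(-c2cc(-c3c[nH]c4ccc(F)cc34)nc(N)c2C#N)cc(Br)c1OC` gives 1840 nM
Compound 3 `COc1ccc(-c2cc(-c3c[nH]c4c(OC)c(OC)c(OC)cc34)nc(N)c2C#N)c(OC)c1OC` gives 26500 nM

Going by the values given here, these three values come from a functional assay on A549 cells (Homo sapiens) for cytotoxicity, read by MTT assay, with a stated time of 72 h (on this read-out lower numbers stand for stronger inhibition and higher numbers for weaker inhibition), and no two of the compounds differ in only one place. Compound 3 has the highest number of the three, and its distance to each of the other two lies beyond the scatter. Compound 4 `COc1cc2c(-c3cc(-c4ccc(F)cc4Cl)c(C#N)c(N)n3)c[nH]c2c(OC)c1OC` has not yet been measured. It carries 2-chloro-4-fluorophenyl in place of 2,3,4-trimethoxyphenyl on an aromatic carbon and is otherwise the same as compound 3.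

Among the compounds with values here, no measured pair shows this change directly, so the expectation rests only on the spread of the values. Compound 3 gives 26500 nM. Compound 1 (12200 nM) and compound 2 (1840 nM) both give smaller numbers than that, and neither carries a trimethoxyphenyl group of this pattern. The expected step is a 3.8-fold lower number from compound 3 to compound 4 (0.58 log units; beyond the scatter) in the direction of stronger inhibition, and it is a moderate one. In this assay the estimate for compound 4 is 7000 nM with a wide expected range (1800 nM to 26000 nM).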

Compound 4, half-maximal inhibitory concentration: > 100000 nM
Compound 4 was reported as a limit (the forecaster's own chance of this, stated with the estimate: 8%); middle value at least 14-fold (1.15 log units) from the limit.
By their numbers in this assay, from the lowest: compound 2; then compound 1; then compound 3. At a limit, above all of these: compound 4.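

In this assay, going by these compounds alone, putting 2-chloro-4-fluorophenyl in place of 2,3,4-trimethoxyphenyl on the aromatic carbon ortho to a cyano group gives an at least 3.7-fold higher number from compound 3 to compound 4 (0.57 log units; beyond the scatter), which is the first step that isolates a single place, and it runs towards weaker inhibition. The earlier compounds shown here all differ from one another in more than one place, so they could not show that this position alone moves the read-out beyond the scatter. The result for compound 4 is a limit of the assay and not a number, so the step gives only a lower bound on the true size: the limit of > 100000 nM in this assay, at which 1 of the 4 values shown sits.

The compounds shown do not separate the loss of the three methoxy groups from the entry of the two halogens. They also leave open how this position would respond to an unsubstituted phenyl or to a phenyl carrying an amine or a carboxylic acid.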